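This account rests on a few compounds, and the source may have more. Where it says the series, first, only, none or still open, it means among the compounds named here.

The study looks at three compounds built on a shared core and at a fourth that has yet to be tested. Compound 1 `C=C1C[C@]23C[C@@]1(O)CC[C@H]2c1ccc(O)c(C)c1[C@@H]3Cn1cc(-c2ccc(C(F)(F)F)cc2)nn1` was tested in a functional assay on SMMC-7721 cells (Homo sapiens) for cytotoxicity, read by MTT assay, with a stated time of 4 days; a lower number here means a stronger inhibitor, a higher number a weaker inhibitor. In this assay compound 1 gives > 20000 nM, which is a limit of the assay and not a number. Compound 2 `C=C1C[C@]23C[C@@]1(O)CC[C@@H]2c1cccc(C)c1[C@@H]3Cn1cc(-c2ccc(Br)cc2)nn1` was tested in the same way. In this assay compound 2 gives > 20000 nM, again a limit rather than a number. Compound 3 `C=C1C[C@]23C[C@@]1(O)CC[C@H]2c1cc(Br)c(O)c(C)c1[C@@H]3Cn1cc(-c2ccccc2)nn1` follows suit. In this assay compound 3 gives > 20000 nM, also a limit. Compound 1 thus stands where both of its companions stand, namely at the limit of > 20000 nM in this assay, at which 3 of the 3 values shown sit. Among the measured compounds shown here, no step between two measured compounds can be read from these values, since each of them is a limit.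

Compound 4 `C=C1C[C@]23C[C@@]1(O)CC[C@H]2c1ccc(O)c(C)c1[C@@H]3Cn1cc(-c2ccc(F)cc2)nn1` is not yet measured. It differs from compound 1 by fluoro in place of trifluoromethyl on an aromatic carbon, in words fluoro in place of trifluoromethyl on an aromatic carbon. Nothing measured here ties such a change to a change in this read-out. The step that the limit leaves unreadable from compound 1 to compound 4 in this assay is expected to be none beyond the scatter. Compound 4 is therefore expected to remain at the same limit, with an estimate in this assay of 30000 nM and a range from 8000 nM to 100000 nM.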

Compound 4, half-maximal inhibitory concentration: > 20000 nM
Compound 4 ended at the assay's limit (the forecaster's own chance of this, stated with the estimate: 85%); the middle value does not contradict the limit.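

Compound 1 and compound 4 each give a limit of the assay and not a number in this assay, so no new step can be read between them: the limit of > 20000 nM in this assay, at which 4 of the 4 values shown sit.

The compounds shown leave open how active any of them is on these cells, and which change to the shared core, if any, would give a readable value.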